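Ester to Acid on a Second Core

The source may hold more compounds than are shown below. What is called first, only, known or untested is meant among the compounds shown, and "the series" means these compounds.

Compound 1 `COC(=O)c1ccc(COc2ccc(CNC(=O)[C@@H]3CCC(=O)N3Cc3ccccc3)cc2)cc1`: in an assay on HEK293 cells for inhibition of Ataxin-2 (Mus musculus), read by fluorescence and Amplex Red (a higher number here means a weaker inhibitor, a lower number a stronger inhibitor), compound 1 gives > 5000 nM, which is a limit of the assay.
Compound 2 `O=C(O)c1ccc(COc2ccc(CNC(=O)[C@@H]3CCC(=O)N3Cc3ccccc3)cc2)cc1`: in this assay compound 2 gives 4500 nM.
Compound 3 `COC(=O)c1ccc(COc2ccc(CN3C(=O)CC[C@H]3Cn3ccnc3)cc2)cc1`: in this assay compound 3 gives > 5000 nM, which is a limit of the assay.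

From compound 1 to compound 2 the change is hydrogen in place of methyl on an oxygen next to a carbonyl group, and it made a step of an at least 1.1-fold lower number from compound 1 to compound 2 (0.04 log units; that floor lies within the scatter). Compound 3 carries a different core; the difference between the two cores is not broken down here. Compound 4 `O=C(O)c1ccc(COc2ccc(CN3C(=O)CC[C@H]3Cn3ccnc3)cc2)cc1` differs from compound 3 by hydrogen in place of methyl on an oxygen next to a carbonyl group, the same change at the same place. Two of the three values sit at the limit of > 5000 nM in this assay, at which 2 of the 3 values shown sit, compound 3 among them. Given that the step from compound 1 to compound 2 stayed within the scatter, a step of a number no higher from compound 3 to compound 4 (the limit leaves the size open) is expected. Compound 4 is therefore estimated at 5000 nM, with a range from 2500 nM to 10000 nM, and a real chance that only a limit is reported.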

Compound 4, half-maximal inhibitory concentration: > 5000 nM
Compound 4: only a limit was reported; the forecaster's own chance of this, stated with the estimate: 55%; the middle value lies on the limit itself.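

Going by these compounds alone, no step from compound 3 to compound 4 can be read, because both values are limits of the assay: the limit of > 5000 nM in this assay, at which 3 of the 4 values shown sit. The compounds shown leave open whether methoxycarbonyl to carboxy changes the inhibition at all on the core of compound 3.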